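A few compounds are considered here, and "the series" means these few. Any claim that something is new, unique, unknown or untested is made for them only; others in the source may bear on it.

Of the compounds shown here, three have been measured in a functional assay on HCT-116 cells (Homo sapiens) for cytotoxicity, read by MTT assay, with a stated time of 72 h; a higher number here means a weaker inhibitor, a lower number a stronger inhibitor. For compound 1 (`O=C(Nc1ccc(Cl)cc1)Nc1ccc(C(=O)NO)cc1`) the assay reports only a limit, > 50000 nM. Compound 2 (`COc1ccc(NC(=O)Nc2ccc(/C=C/C(=O)NO)cc2)cc1`) gives 11900 nM. Compound 3 (`O=C(/C=C/c1ccc(NC(=O)Nc2ccc([N+](=O)[O-])cc2)cc1)NO`) gives 12600 nM, which places it level with compound 2. Within the data shown here, the only measured step is a 1.1-fold higher number from compound 2 to compound 3 (0.02 log units; within the scatter), with nitro in place of methoxy on an aromatic carbon.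

Compound 4 (`O=C(CCc1ccc(NC(=O)Nc2ccc([N+](=O)[O-])cc2)cc1)NO`) keeps the nitro group of compound 3 and alters the chain instead: 2-(hydroxycarbamoyl)ethyl in place of 2-(hydroxycarbamoyl)ethenyl on an aromatic carbon, para to a large group (2-(hydroxycarbamoyl)ethyl in place of 2-(hydroxycarbamoyl)ethenyl on an aromatic carbon). Among the measured compounds shown here, no measured step touches this chain, so the data offer no direct guide to the change. For the measured compounds named here, the one step available, a 1.1-fold higher number from compound 2 to compound 3 (0.02 log units; within the scatter), concerns a different place and can only hint that the numbers need not move far. In this assay, going by the values given here, no step far beyond the scatter is therefore expected, and a higher number is the somewhat likelier direction, though nothing measured settles it. The estimated step is a 1.4-fold higher number from compound 3 to compound 4 (0.15 log units; within the scatter). For compound 4 the expected value is 18000 nM, with an estimated range from 7000 nM to 50000 nM.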

Compound 4, half-maximal inhibitory concentration: 6370 nM
The estimate for compound 4 lay 2.8-fold (0.45 log units) above the measured number; measured number below the stated range.
By their numbers in this assay, from the lowest: compounds 4, 2 and 3 (each within the scatter of the next). At a limit, above all of these: compound 1.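

In this assay, among these compounds, the first measured change at this position, on an aromatic carbon para to a large group, is 2-(hydroxycarbamoyl)ethyl in place of 2-(hydroxycarbamoyl)ethenyl, and it amounts to a 2.0-fold lower number from compound 3 to compound 4 (0.30 log units; within the scatter). With the nitro group held constant, the chain can therefore give up one double bond outside aromatic rings without the number leaving the scatter, although this rests on a single pair and supports no wider pattern. Nothing among the available data gives a cause for this result.

As far as these compounds go, it remains open whether a longer chain, or a carboxylic acid in place of the hydroxycarbamoyl end, would leave the number similarly unmoved, and whether the same exchange of chains would read alike with the methoxy group of compound 2 or with an amine on the far ring. Compound 1 gives only a limit, > 50000 nM, and it differs from the others in more than one place, so it cannot settle what a chain attached directly through the hydroxycarbamoyl group would do.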